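Amide to urea swap in the sulfonate ester series

The source may report more compounds than this note shows. Statements on the series, on what has been measured and on what is new or still open speak of the compounds shown alone.

In a functional assay on HT-1080 cells (Homo sapiens) for antiproliferative activity, read by sulforhodamine B assay, with a stated time of 48 h (on this read-out lower numbers stand for stronger inhibition and higher numbers for weaker inhibition), compound 3 `CC(C)c1ccccc1OS(=O)(=O)c1ccc(NC(=O)CCCCl)cc1` gives 3800 nM, the second highest of the three numbers, within the scatter of compound 2 `CC(C)c1ccccc1OS(=O)(=O)c1ccc(NC(=O)CCCl)cc1` at 6500 nM and of compound 1 `CCC(=O)Nc1ccc(S(=O)(=O)Oc2ccccc2C(C)C)cc1` at 2100 nM. Compound 4 `CCCNC(=O)Nc1ccc(S(=O)(=O)Oc2ccccc2C(C)C)cc1` is not yet measured; it differs from compound 3 by propylamino in place of 3-chloropropyl on a carbonyl carbon. Within the data shown here, no measured step covers this change directly: the steps of a 3.1-fold higher number from compound 1 to compound 2 (0.49 log units; beyond the scatter), a 1.8-fold higher number from compound 1 to compound 3 (0.26 log units; within the scatter) and a 1.7-fold lower number from compound 2 to compound 3 (0.23 log units; within the scatter) all concern a saturated chain carbon and stay small. Variation at the acyl part has so far moved this assay little, so compound 4 is expected to land close to compound 3, likely within the scatter. The step expected for compound 4 is a 1.3-fold lower number from compound 3 to compound 4 (0.10 log units; within the scatter). The estimate for compound 4 is 3000 nM, between 1000 nM and 9000 nM.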

Compound 4, half-maximal inhibitory concentration: 680 nM
Compound 4: middle estimate off by 4.4-fold (0.64 log units), on the high side, outside the stated range (below it).
By their numbers in this assay, from the lowest: compound 4; then compounds 1, 3 and 2 (each within the scatter of the next, the first and the last beyond it).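

In this assay, propylamino on the carbonyl carbon gives a step beyond the scatter against each of the three carbon-chain amides (a 5.6-fold lower number from compound 3 to compound 4 (0.75 log units; beyond the scatter); a 9.6-fold lower number from compound 2 to compound 4 (0.98 log units; beyond the scatter); a 3.1-fold lower number from compound 1 to compound 4 (0.49 log units; beyond the scatter)). This position therefore responds more to the change from a carbon chain to propylamino than to the earlier chain variations, and compound 4 has the lowest number of the four. Nothing available explains this difference.

As far as these compounds go, it remains open how ethylamino, butylamino or anilino would read in place of propylamino on the carbonyl carbon. From the compounds shown here alone, whether propoxy there would match the step also remains open.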